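The source may report more compounds than this note shows. Statements on the series, on what has been measured and on what is new or still open speak of the compounds shown alone.

Measured so far:
Compound 1 `CN(c1ccc(Oc2ncnc3ccsc23)cc1)c1nccc(N2CCc3ccccc32)n1` gives 57.8%.
Compound 2 `CN(c1ccc(Oc2ncnc3sccc23)cc1)c1nccc(N2CCc3ccccc3C2)n1` gives 57.7%.
Compound 3 `c1ccc2c(c1)CCN2c1ccnc(Nc2ccc(Oc3ncnc4sccc34)cc2)n1` gives -0.62%.

The study concerns a shared core tested in a functional assay on HCT-116 cells (Homo sapiens) for inhibition, read by MTT assay, with a stated time of 72 h, tested at 20 uM; a higher number here means more inhibition at the concentration tested (going by the name of the read-out), a lower number less inhibition. Compound 3 stands lowest of the three numbers: its nearest neighbour is compound 2, whose number lies beyond the scatter above it, and compound 1 lies a little further still, also beyond the scatter. Compound 1 and compound 2 sit within the scatter of each other.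

The step from compound 3 to compound 4 `CN(c1ccc(Oc2ncnc3sccc23)cc1)c1nccc(N2CCc3ccccc32)n1` is methyl in place of hydrogen on a nitrogen on an aromatic ring. Compound 1 and compound 2 both carry a methyl at this nitrogen, and both give numbers far above compound 3, whereas compound 3 carries hydrogen there. On that basis the step from compound 3 to compound 4 in this assay is expected to be large and upward, of the order of the gap separating compound 3 from compound 1 and compound 2, giving a number 55.6 percentage points higher from compound 3 to compound 4 (beyond the scatter).

Compound 4 is therefore estimated at 55%, within a range of 35% to 72%.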

Compound 4, a percentage reported as inhibition, at one concentration (the size of the read-out at that concentration, not a potency): 20%
Compound 4: the middle estimate sits 35 percentage points above what was measured; measured number outside the range, below it.
By their numbers in this assay, from the lowest: compound 3; then compound 4; then compounds 2 and 1 (each within the scatter of the next).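

Within this assay methyl in place of hydrogen on a nitrogen on an aromatic ring gives a number 20.6 percentage points higher from compound 3 to compound 4 (beyond the scatter) and so does raise the number, but this single pair shows that the methyl accounts for only part of what compound 1 and compound 2 reach. With that methyl kept, 2,3-dihydro-1H-indol-1-yl in place of 1,2,3,4-tetrahydroisoquinolin-2-yl on an aromatic carbon gives a number 37.7 percentage points lower from compound 2 to compound 4 (beyond the scatter) and exchanging one group of 9 heavy atoms for another on an oxygen on an aromatic ring gives a number 37.8 percentage points lower from compound 1 to compound 4 (beyond the scatter) so both of these other places matter at least as much here as the nitrogen does. Nothing available explains the size of any of these steps.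

The compounds shown leave open whether an ethyl or an acetyl group on that nitrogen would carry the number further than methyl does. They also leave open whether the methyl step would keep its size on the cores of compound 1 and compound 2.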